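Ethynyl in Place of Benzofuranyl on a Shared Nucleoside Core

This account rests on a few compounds, and the source may have more. Where it says the series, first, only, none or still open, it means among the compounds named here.

Of the compounds shown here, three have been measured in a functional assay on HCT-116 cells (Homo sapiens), read by MTT assay, with a stated time of 72 h; on this read-out higher numbers stand for weaker inhibition and lower numbers for stronger inhibition.
Compound 1 `C#Cc1cn([C@@H]2O[C@H](CO)[C@@H](O)[C@H]2O)c2ncnc(OC)c12` gives 4060 nM.
Compound 2 `COc1ncnc2c1c(-c1ccccc1)cn2[C@@H]1O[C@H](CO)[C@@H](O)[C@H]1O` gives only a limit of the assay, > 20000 nM.
Compound 3 `CN(C)c1ncnc2c1c(-c1cc3ccccc3o1)cn2[C@@H]1O[C@H](CO)[C@@H](O)[C@H]1O` likewise gives only a limit of the assay, > 20000 nM.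

Compound 3 therefore stands at the edge of what this assay reports, with no number of its own, and it shares this position with compound 2, as the limit of > 20000 nM in this assay, at which 2 of the 3 values shown sit, shows. Compound 4 `C#Cc1cn([C@@H]2O[C@H](CO)[C@@H](O)[C@H]2O)c2ncnc(N(C)C)c12` differs from compound 3 by one change: ethynyl in place of 1-benzofuran-2-yl on an aromatic carbon. Among the compounds with values here, the single measured step that bears on this is an at least 4.9-fold higher number from compound 1 to compound 2 (0.69 log units; beyond the scatter), which runs the opposite way, an aromatic ring entering where ethynyl had been and pushing the number up to the limit. Going back from a fused ring to ethynyl is therefore expected to lower the number, with compound 1 as the nearest measured guide, although compound 4 and compound 1 also differ elsewhere on the core, a difference no measured step covers on its own. Compound 4 is estimated at 4500 nM, expected to lie between 1500 nM and 14000 nM, an expected step of an at least 4.4-fold lower number from compound 3 to compound 4 (0.64 log units; beyond the scatter).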

Compound 4, half-maximal inhibitory concentration: 180 nM
For compound 4 the middle estimate is 25-fold (1.40 log units) above the measured one, and the stated range ends above it.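

In this assay, the change from 1-benzofuran-2-yl to ethynyl gives an at least 110-fold lower number from compound 3 to compound 4 (2.04 log units; beyond the scatter), so ethynyl is again favoured over an aromatic group at this position, now with dimethylamino rather than methoxy on the shared core. The earlier compounds shown here also said nothing on that second place, where dimethylamino in place of methoxy, with ethynyl kept, gives a 23-fold lower number from compound 1 to compound 4 (1.35 log units; beyond the scatter), so the number depends strongly on this group as well as on the ethynyl. The full size of the first step remains unknown because compound 3 sits at a limit of the assay: the limit of > 20000 nM in this assay, at which 2 of the 4 values shown sit.

As far as these compounds go, it remains open whether ethynyl itself is required or whether a nitrile, a vinyl group or a methyl group would serve on this aromatic carbon. Also open, from the compounds shown here alone, is how a primary amine or a pyrrolidine would compare with dimethylamino.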